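Adding Methoxy to Compound 3

The compounds below may be only part of what the source reports. "The series", "measured", "known", "first", "only" and "open" are said of these compounds alone.

Of the compounds shown here, three have been tested in a functional assay on PC-3 cells (Homo sapiens) for antiproliferative activity, read by sulforhodamine B assay, with a stated time of 48 h; on this read-out higher numbers stand for weaker inhibition of growth and lower numbers for stronger inhibition of growth. Compound 1 `COc1ccc(S(=O)(=O)c2ccc3c(/C=C/C(=O)NO)cccc3n2)cc1` returns only a limit of the assay, > 10000 nM. Compound 2 `COc1ccc(S(=O)(=O)c2ccc3cc(/C=C/C(=O)NO)ccc3n2)cc1` gives 1350 nM, and compound 3 `O=C(/C=C/c1cccc(S(=O)(=O)c2ccc3ccccc3n2)c1)NO` gives 150 nM. Compound 3 thus holds the lower of the two actual numbers, and its gap to compound 2 lies beyond the scatter.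

Compound 4 `COc1ccc2nc(S(=O)(=O)c3cccc(/C=C/C(=O)NO)c3)ccc2c1` differs from compound 3 in one place: methoxy in place of hydrogen on an aromatic carbon. Methoxy stands in place of hydrogen on an aromatic carbon of a six-membered aromatic ring of carbon only, part of a fused or bridged system of two rings. Within the data shown here, no pair of measured compounds shows this change alone, so its size cannot be read directly from the data. The estimate therefore starts from compound 3 at 150 nM. In this assay, a small move toward a higher number is expected, with no step beyond the scatter: a 1.3-fold higher number from compound 3 to compound 4 (0.12 log units; within the scatter). For compound 4 the estimated value is 200 nM, with an expected range from 60 nM to 700 nM.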

Compound 4, concentration for 50% growth inhibition: 280 nM
Compound 4: middle estimate off by 1.4-fold (0.15 log units), on the low side, and the stated range covers the measured number.
By their numbers in this assay, from the lowest: compounds 3 and 4 (each within the scatter of the next); then compound 2. At a limit, above all of these: compound 1.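

In this assay, among these compounds, the first direct reading of this change is a 1.9-fold higher number from compound 3 to compound 4 (0.27 log units; within the scatter), for methoxy in place of hydrogen on an aromatic carbon. Among the compounds shown here, the position, meta to a fused ring and para to a fused ring, thus accepts a group of 2 heavy atoms with 1 hydrogen-bond acceptor without a step beyond the scatter, which the earlier compounds could not show. Nothing in the data shown accounts for the size of this step.

On these data alone, whether an amine, a carboxylic acid or a longer chain such as ethoxy at this same carbon would also stay within the scatter of compound 3 remains open. As far as these compounds go, it is equally open whether methoxy on another carbon of this ring would give a step of similar size.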